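Thromboxane synthase series: sulfur for oxygen at the aryl link

This account rests on a few compounds, and the source may have more. Where it says the series, first, only, none or still open, it means among the compounds named here.

Measured compounds:
compound 1 `O=C(O)CC/C=C\CC1COC(c2ccco2)OC1c1cccnc1` — 164 nM
compound 2 `CC(C)(Oc1ccccc1)C1OCC(C/C=C\CCC(=O)O)C(c2cccnc2)O1` — 52 nM
compound 3 `CC(C)(Oc1ccc(F)cc1)C1OCC(C/C=C\CCC(=O)O)C(c2cccnc2)O1` — 51 nM

All three were run in an assay for inhibition of Thromboxane-A synthase (Homo sapiens), using microsomes; on this read-out higher numbers stand for weaker inhibition and lower numbers for stronger inhibition. Compound 3 gives the lowest of the three numbers, but its nearest neighbour is compound 2, which differs only within the scatter, so no order between compound 2 and compound 3 can be read. Going by the values given here, the one step that clearly moves the read-out is a 3.2-fold lower number from compound 1 to compound 2 (0.50 log units; beyond the scatter). The second step, a 1.0-fold lower number from compound 2 to compound 3 (0.01 log units; within the scatter), leaves the number where it was.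

Compound 4 `CC(C)(Sc1ccccc1)C1OCC(C/C=C\CCC(=O)O)C(c2cccnc2)O1` has not yet been measured in this assay. Its change from compound 3 is phenylsulfanyl in place of 4-fluorophenoxy on a saturated chain carbon bound to two saturated chain carbons and a saturated ring carbon. No measured step swaps the linking atom in this way, so the only direct precedent is the fluoro-for-hydrogen step, which was flat; the exchange of one six-membered aromatic ring for another with a changed link has no shown analogue. The expectation is therefore no step beyond the scatter, with a 1.1-fold higher number from compound 3 to compound 4 (0.03 log units; within the scatter) as the estimated change. Compound 4 is expected at about 55 nM, in the range 25 nM to 130 nM.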

Compound 4, half-maximal inhibitory concentration: 40 nM
The estimate for compound 4 lay 1.4-fold (0.14 log units) above the measured number, and the stated range covers the measured number.
By their numbers in this assay, from the lowest: compounds 4, 3 and 2 (each within the scatter of the next); then compound 1.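

In this assay the linking atom at this saturated chain carbon can be exchanged without a readable shift: phenylsulfanyl in place of phenoxy gives a 1.3-fold lower number from compound 2 to compound 4 (0.11 log units; within the scatter), and phenylsulfanyl in place of 4-fluorophenoxy gives a 1.3-fold lower number from compound 3 to compound 4 (0.11 log units; within the scatter). The sulfur-linked group also stands clear of the group with the five-membered aromatic ring on the saturated ring carbon, with a 4.1-fold lower number from compound 1 to compound 4 (0.61 log units; beyond the scatter), so the step beyond the scatter is no longer tied to the oxygen link alone. No supporting evidence bears on this result.

Still open, on these data alone, is whether 4-fluorophenylsulfanyl reads like phenylsulfanyl at this saturated chain carbon. An amine link or a sulfone link in the same place would test how far the link can change before the number moves beyond the scatter.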